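A few compounds are considered here, and "the series" means these few. Any claim that something is new, unique, unknown or untested is made for them only; others in the source may bear on it.

Measured so far in an assay for inhibition of zeta-carotene desaturase, chloroplastic/chromoplastic (Capsicum annuum), using a Dixon plot, with a stated time of 8 h; a higher number here means a weaker inhibitor, a lower number a stronger inhibitor:
compound 1, `CCC(COc1ccccc1)OC(=O)NCc1ccccc1`, gives > 100000 nM
compound 2, `CCC(COc1cccc(Br)c1)OC(=O)NCc1ccccc1`, gives > 100000 nM

Both entries are limits of this assay, not numbers. Compound 2 stands at that limit with > 100000 nM. Compound 1 sits at the same limit (the limit of > 100000 nM in this assay, at which 2 of the 2 values shown sit). Within the data shown here, the only measured step, a step that the two limits leave unreadable from compound 1 to compound 2, runs between two limits and therefore has no readable size.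

Compound 3, `CCC(COc1cccc(C(C)C)c1)OC(=O)NCc1ccccc1`, differs from compound 2 by isopropyl in place of bromo on an aromatic carbon. Among the measured compounds shown here, the one step that bears on this position, a step that the two limits leave unreadable from compound 1 to compound 2, gives no size and no direction. No measured change at this position has moved the read-out off the limit, so compound 3 is expected to stay near the limit in this assay, with an estimated step that the limit leaves unreadable from compound 2 to compound 3. Compound 3 is therefore estimated at 150000 nM, with an expected range from 30000 nM to 1000000 nM.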

Compound 3, half-maximal inhibitory concentration: > 100000 nM
Compound 3: a limit, no number; the forecaster's own chance of this, stated with the estimate: 85%; the middle value lies beyond the limit too.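

In this assay compound 3 gives > 100000 nM, a limit and not a number. The steps to compound 3 from compound 1 and compound 2 therefore cannot be read. The compounds shown leave open whether any substituent on this aromatic ring moves the read-out off the limit.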